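The compounds below may be only part of what the source reports. "The series", "measured", "known", "first", "only" and "open" are said of these compounds alone.

Measured so far in an assay on isolated protein for inhibition of protein kinase C zeta type (Homo sapiens), with stated times of 1 h and 2.5 min, tested at 30 uM; on this read-out higher numbers stand for more inhibition at the one concentration tested (going by the name of the read-out) and lower numbers for less inhibition:
compound 1 `Cc1cccc(-c2csc(N)c2C(=O)OCc2ccccc2)c1`, 68%;
compound 2 `Cc1ccc(-c2csc(N)c2C(=O)OCc2ccccc2)cc1`, 60%;
compound 3 `COc1ccc(-c2csc(N)c2C(=O)OCc2ccccc2)cc1`, 86%.

Compound 3 stands highest of the three, with both steps to it beyond the scatter: a number 18 percentage points higher from compound 1 to compound 3 (beyond the scatter) and a number 26 percentage points higher from compound 2 to compound 3 (beyond the scatter). Between compound 1 and compound 2 the step is within the scatter: a number 8 percentage points lower from compound 1 to compound 2 (within the scatter).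

Compound 4 `Nc1scc(-c2ccccc2F)c1C(=O)OCc1ccccc1` is not yet measured. Its change from compound 3: 2-fluorophenyl in place of 4-methoxyphenyl on an aromatic carbon. For the measured compounds named here, no measured step covers a fluorine or a 2-substituted phenyl. The two steps that bear on it are those that gained the methoxy, a number 26 percentage points higher from compound 2 to compound 3 (beyond the scatter) and a number 18 percentage points higher from compound 1 to compound 3 (beyond the scatter), both modest rises; its loss here is expected to cost a similar modest amount in this assay, a number 24 percentage points lower from compound 3 to compound 4 (beyond the scatter). Compound 4 is therefore expected at about 62%, in the range 45% to 80%.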

Compound 4, a percentage reported as inhibition, at one concentration (the size of the read-out at that concentration, not a potency): 57%
Compound 4: middle estimate off by 5 percentage points, on the high side; low and high end bracket the measured number.
By their numbers in this assay, from the lowest: compounds 4, 2 and 1 (each within the scatter of the next, the first and the last beyond it); then compound 3.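

For the compounds shown here, at this aromatic carbon in this assay, 2-fluorophenyl in place of 4-methoxyphenyl lowers the number (a number 29 percentage points lower from compound 3 to compound 4 (beyond the scatter)), the first reading for a fluorine or a 2-substituted phenyl. Against the methyl compounds, it shows no separation from 4-methylphenyl (a number 3 percentage points lower from compound 2 to compound 4 (within the scatter)) and stands under 3-methylphenyl (a number 11 percentage points lower from compound 1 to compound 4 (beyond the scatter)), so 4-methoxyphenyl alone stands apart upward among these four groups. No measurement at hand explains these differences.

Open, from the compounds shown here alone, is whether the higher number follows the methoxy itself or its place on the phenyl, which 2-methoxyphenyl and 4-fluorophenyl would separate. Also open, going by these compounds, is how an amine or a carboxylic acid on the phenyl would read.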